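The source may hold more compounds than are shown below. What is called first, only, known or untested is meant among the compounds shown, and "the series" means these compounds.

Of the compounds shown here, three have been measured in an assay on HEK293 cells for inhibition of prostaglandin E2 receptor EP2 subtype (Rattus norvegicus); a lower number here means a stronger inhibitor, a higher number a weaker inhibitor. Compound 1 `CC(C)(C)c1ccc(CN(Cc2cccc(CCC(=O)O)c2)S(=O)(=O)c2nccs2)cc1` gives 63 nM, the lowest of the three numbers. Compound 2 `CCCCc1ccc(CN(Cc2cccc(CCC(=O)O)c2)S(C)(=O)=O)cc1` gives 270 nM, and compound 3 `CCCCc1ccc(CN(Cc2ccccc2OCC(=O)O)S(C)(=O)=O)cc1` gives 3200 nM; both of these stand beyond the scatter from compound 1. Compound 4 `CC(C)(C)c1ccc(CN(Cc2cccc(CCC(=O)O)c2)S(=O)(=O)c2ccccn2)cc1` has not yet been measured. It differs from compound 1 in a single place: pyridin-2-yl in place of 1,3-thiazol-2-yl on a sulfonyl sulfur. Within the data shown here, no measured pair shows this exchange, so its size cannot be read from the numbers so far. Both groups are a single aromatic ring sitting on the sulfonyl sulfur, and the step of a 1.3-fold higher number from compound 1 to compound 4 (0.10 log units; within the scatter) is expected to be small, near or just beyond the scatter, in either direction. Compound 4 is therefore estimated at 80 nM in this assay, within a range from 25 nM to 250 nM.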

Compound 4, half-maximal inhibitory concentration: 52 nM
The estimate for compound 4 lay 1.5-fold (0.19 log units) above the measured number; the range from low to high includes it.
By their numbers in this assay, from the lowest: compounds 4 and 1 (each within the scatter of the next); then compound 2; then compound 3.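

Among these compounds, with a 1.2-fold lower number from compound 1 to compound 4 (0.08 log units; within the scatter) in this assay the first direct exchange at this position, pyridin-2-yl in place of 1,3-thiazol-2-yl on a sulfonyl sulfur, leaves the number unchanged within the usual scatter. A six-membered aromatic ring with one hetero atom therefore serves here as well as a five-membered aromatic ring with two. Nothing available explains this match. Still open, on these data alone, is whether a plain phenyl ring, without a ring nitrogen, would serve equally well. Whether a non-aromatic group, such as cyclohexyl or a longer alkyl chain, would do so is also unknown.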